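Phenyl for 3,5-dimethoxyphenyl: a small step expected

The source may hold more compounds than are shown below. What is called first, only, known or untested is meant among the compounds shown, and "the series" means these compounds.

Values measured in a functional assay on HeLa cells (Homo sapiens) for antiproliferative activity, read by MTT assay, with a stated time of 72 h (a higher number here means a weaker inhibitor, a lower number a stronger inhibitor), are
- compound 1 `CCc1cccc(NC(=O)C(=O)[C@H](CC(C)C)NC(=O)[C@H](CC(C)C)NC(=O)[C@H](CC(C)C)NC(=O)OCc2ccccc2)c1` gives 212 nM
- compound 2 `COc1cc(NC(=O)C(=O)[C@H](CC(C)C)NC(=O)[C@H](CC(C)C)NC(=O)[C@H](CC(C)C)NC(=O)OCc2ccccc2)cc(OC)c1` gives 120 nM

Compound 2 and compound 1 lie within the scatter of each other, so the two numbers cannot be ranked. Compound 3 `CC(C)C[C@H](NC(=O)OCc1ccccc1)C(=O)N[C@@H](CC(C)C)C(=O)N[C@@H](CC(C)C)C(=O)C(=O)Nc1ccccc1` carries phenyl in place of 3,5-dimethoxyphenyl on an amide-type nitrogen. Within the data shown here, the only measured step that bears on this changes the group on that same nitrogen, and it is small (a 1.8-fold lower number from compound 1 to compound 2 (0.25 log units; within the scatter)). One step is thin evidence, so in this assay no change beyond the scatter is expected, and the direction is a cautious guess. The estimated step is a 1.4-fold higher number from compound 2 to compound 3 (0.15 log units; within the scatter) and would stay small. For compound 3 the expected value is 170 nM with 60 nM to 480 nM as the estimated range.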

Compound 3, half-maximal inhibitory concentration: 288 nM
Beside the measured number, compound 3's estimate is 1.7-fold (0.23 log units) below it; low and high end bracket the measured number.
By their numbers in this assay, from the lowest: compounds 2, 1 and 3 (each within the scatter of the next, the first and the last beyond it).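

In this assay, phenyl in place of 3,5-dimethoxyphenyl on the amide-type nitrogen gives a 2.4-fold higher number from compound 2 to compound 3 (0.38 log units; beyond the scatter) and is the first change shown here at this position to pass the scatter. Hydrogen in place of ethyl on an aromatic carbon gives a 1.4-fold higher number from compound 1 to compound 3 (0.13 log units; within the scatter) and leaves compound 1 and compound 3 unranked. Nothing available explains the step from compound 2 to compound 3. As far as these compounds go, whether one methoxy group would give the same result as two remains open. So does the effect of an amine or a carboxylic acid on this ring.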